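Removing Iodine from Two Unrelated Cores

A few compounds are considered here, and "the series" means these few. Any claim that something is new, unique, unknown or untested is made for them only; others in the source may bear on it.

Compound 1, with the structure `CC(=O)OCCOCn1cnc2c(Cl)nc(I)nc21`, is the starting point of this small set. In an ADME assay on L1210/0 cells (Mus musculus) for cytotoxicity, with a stated time of 48 h (on this read-out higher numbers stand for weaker inhibition and lower numbers for stronger inhibition), compound 1 gives 8600 nM. Compound 2, `CC(=O)OCCOCn1cnc2c(Cl)ncnc21`, differs from it by hydrogen in place of iodo on an aromatic carbon, and in this assay compound 2 gives 163000 nM. The resulting step, a 19-fold higher number from compound 1 to compound 2 (1.28 log units; beyond the scatter), is a large one.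

Compound 3, `CC1(C)[C@@H](CO)CC[C@@]1(C)Cn1cc(I)c(=O)[nH]c1=O`, is built on a different core; the difference between the two cores is not broken down here. For compound 3 in this assay only a limit is known, > 200000 nM. That limit is the one described by the limit of > 200000 nM in this assay, at which 1 of the 3 values shown sits.

Compound 4, `CC1(C)[C@@H](CO)CC[C@@]1(C)Cn1ccc(=O)[nH]c1=O`, has not yet been measured in this assay. It differs from compound 3 by hydrogen in place of iodo on an aromatic carbon. This is the same kind of change as that from compound 1 to compound 2, though the surroundings differ: in compound 1 the place is between two ring nitrogen atoms, meta to a chloro group (1 heavy atom), meta to a fused ring and para to a fused ring, whereas in compound 3 it is ortho to a group of 1 heavy atom, two atoms from the ring nitrogen, meta to a large group and para to a group of 1 heavy atom.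

Because the earlier step of this kind was a 19-fold higher number from compound 1 to compound 2 (1.28 log units; beyond the scatter), compound 4 is expected to give a higher number than compound 3, whose value is already only a limit. Compound 4 is therefore estimated at 600000 nM in this assay, between 200000 nM and 3000000 nM, and most likely reported only as a limit. The step this estimate means is expected to be a step that the limit leaves unreadable from compound 3 to compound 4.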

Compound 4, half-maximal inhibitory concentration: > 200000 nM
Compound 4: only a limit was reported; the forecaster's own chance of this, stated with the estimate: 85%; the middle value lies beyond the limit too.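

In this assay compound 4 gives > 200000 nM as a limit and not a number. Compound 3 also stands at a limit, and no step can be read from compound 3 to compound 4 because both values are limits: the limit of > 200000 nM in this assay, at which 2 of the 4 values shown sit. The compounds shown leave open whether hydrogen in place of iodo changes the read-out on the core of compound 3 as it does on the core of compound 1.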